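The compounds below may be only part of what the source reports. "The series", "measured", "known", "first", "only" and "open" are said of these compounds alone.

Working notes on the series, part one.

Within the data shown here, compound 2 `CC(=O)OC[C@H]1O[C@@H](n2cc(CN3C(=O)/C(=C/c4ccc(N(C)C)cc4)c4ccccc43)nn2)[C@H](OC(C)=O)[C@@H](OC(C)=O)[C@@H]1OC(C)=O` gives the highest of the two numbers so far in a functional assay on A549 cells (Homo sapiens) for cytotoxicity, read by sulforhodamine B assay, with a stated time of 48 h (on this read-out higher numbers stand for weaker inhibition and lower numbers for stronger inhibition), where compound 2 gives 19400 nM. Its nearest neighbour is compound 1 `CC(=O)OC[C@H]1O[C@@H](n2cc(CN3C(=O)/C(=C\c4ccc(N(C)C)cc4)c4ccccc43)nn2)[C@H](OC(C)=O)[C@@H](OC(C)=O)[C@@H]1OC(C)=O`, and in this assay compound 1 gives 17700 nM. Among the measured compounds shown here, the step of a 1.1-fold higher number from compound 1 to compound 2 (0.04 log units; within the scatter) is the only measured step, and it rests on the fact that (the fact that compounds 1 and 2 differ only in the configuration as drawn); it shows no effect beyond the scatter.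

The next compound, compound 3 `CC(=O)OC[C@H]1O[C@@H](n2cc(CN3C(=O)/C(=C/c4ccco4)c4ccccc43)nn2)[C@H](OC(C)=O)[C@@H](OC(C)=O)[C@@H]1OC(C)=O`, is reached from compound 2 by one change: furan-2-yl in place of 4-(dimethylamino)phenyl on a double-bonded chain carbon bound to a double-bonded ring carbon. For the measured compounds named here, no measured step concerns an exchange of this kind; the one measured step, a 1.1-fold higher number from compound 1 to compound 2 (0.04 log units; within the scatter), changes only the drawn configuration and leaves the aryl group in place, so it gives no direction for the present change. The expectation for this assay is therefore a step of no clear direction, with the number for compound 3 taken near that of compound 2 and a wide range on either side. The step expected from this reasoning is a 1.0-fold higher number from compound 2 to compound 3 (0.01 log units; within the scatter). On that basis compound 3 is estimated at 20000 nM, expected to fall between 6000 nM and 65000 nM.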

Compound 3, half-maximal inhibitory concentration: 14500 nM
Compound 3: the middle estimate sits 1.4-fold (0.14 log units) above what was measured; the range from low to high includes it.
By their numbers in this assay, from the lowest: compounds 3, 1 and 2 (each within the scatter of the next).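

In this assay, the exchange of 4-(dimethylamino)phenyl for furan-2-yl on a double-bonded chain carbon bound to a double-bonded ring carbon gives a 1.3-fold lower number from compound 2 to compound 3 (0.13 log units; within the scatter). Among these compounds, this is the first measured change of the aryl group itself rather than of the drawn configuration, and it shows that a five-membered aromatic ring with 1 hetero atom and 5 heavy atoms can take the place of a six-membered aromatic ring of carbon only, counted with its substituent at 9 heavy atoms, with no effect beyond the scatter. The information at hand gives no account of why the number holds across this exchange.

As far as these compounds go, whether another group at this place, such as a 4-hydroxyphenyl, a pyridin-3-yl or a carboxylic acid, would move the number beyond the scatter remains open. Among the compounds shown here, also open is whether a furan-2-yl compound with the double bond drawn Z would stand as close to compound 3 as compound 1 stands to compound 2, and the series so far holds no step beyond the scatter.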